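Replacing a Small Ring Amide with a Dimethylmorpholine Urea

The compounds below may be only part of what the source reports. "The series", "measured", "known", "first", "only" and "open" are said of these compounds alone.

Three compounds share a core in which an azetidine carries an oxadiazole bearing a halogen-substituted phenyl ring. Compound 1 `O=C([C@H]1CC2CCC1C2)N1CC(c2nc(-c3cccc(F)c3)no2)C1` and compound 3 `O=C([C@@H]1CC2CCC1C2)N1CC(c2nc(-c3cccc(F)c3)no2)C1` have the same atoms and bonds and differ only in one stereocentre; in an assay on HEK293 cells for positive allosteric modulation of metabotropic glutamate receptor 5 (Homo sapiens), read by FLIPR (on this read-out lower numbers stand for an effect already at smaller amounts and higher numbers for an effect only at larger amounts of compound), compound 1 gives 72 nM and compound 3 gives 100 nM, so the step of a 1.4-fold higher number from compound 1 to compound 3 (0.14 log units; within the scatter) is a small one. Compound 2 `O=C(C1CCCO1)N1CC(c2nc(-c3cccc(Cl)c3)no2)C1` carries a different amide part and a chlorine on the phenyl ring. In this assay compound 2 reaches only a limit, > 10000 nM, which is a boundary of the assay rather than a number.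

The step from compound 2 to compound 4 `CC1CN(C(=O)N2CC(c3nc(-c4cccc(Cl)c4)no3)C2)CC(C)O1` changes the amide part: 2,6-dimethylmorpholin-4-yl in place of oxolan-2-yl on a carbonyl carbon. Within the data shown here, no measured step touches this place, and the one measured step, a 1.4-fold higher number from compound 1 to compound 3 (0.14 log units; within the scatter), concerns only stereochemistry, so it gives no direction here. Among the measured compounds shown here, the only guidance is that, with a larger bicyclic amide, compound 1 gives 72 nM and compound 3 gives 100 nM. Compound 2, by contrast, reaches only a limit of the assay. Compound 4 is expected to fall between these, with an estimated value of 3000 nM (range 300 nM to 30000 nM), meaning an expected step of an at least 3.3-fold lower number from compound 2 to compound 4 (0.52 log units; beyond the scatter).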

Compound 4, half-maximal effective concentration: > 10000 nM
Compound 4 gave a limit, no number; the forecaster's own chance of this, stated with the estimate: 40%; at least 3.3-fold (0.52 log units) between middle value and limit.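

Compound 2 and compound 4 both end at a limit of the assay, not a number, so no step can be read between them: the limit of > 10000 nM in this assay, at which 2 of the 4 values shown sit.

The compounds shown leave open whether 2,6-dimethylmorpholin-4-yl or oxolan-2-yl on the carbonyl carbon gives the lower number.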